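The source may hold more compounds than are shown below. What is called first, only, known or untested is meant among the compounds shown, and "the series" means these compounds.

Measured so far:
compound 1 `Cn1c(Cc2nn(C)c(=O)c3ccccc23)nnc1SCCCCCCCC(=O)Nc1ccc(F)cc1F` — 2300 nM
compound 2 `CCCOc1ccc(NC(=O)CCCCCCCSc2nnc(Cc3nn(C)c(=O)c4ccccc34)n2C)cc1` — 1600 nM

Both were read in an assay on isolated protein (Mus musculus) for inhibition of IL15-IL15 receptor (Homo sapiens), read by resazurin assay, with stated times of 30 min and 2.5 days; on this read-out lower numbers stand for stronger inhibition and higher numbers for weaker inhibition. Compound 2 stands at one of two numbers, with compound 1 nearest; the step of a 1.4-fold lower number from compound 1 to compound 2 (0.16 log units; within the scatter) is within the scatter, so the two are not told apart. Compound 3 `CC(C)Oc1ccc(NC(=O)CCCCCCCSc2nnc(Cc3nn(C)c(=O)c4ccccc34)n2C)cc1` differs from compound 2 by isopropyl in place of propyl on an oxygen on an aromatic ring. Going by the values given here, no measured step touches the group on this oxygen; the one step on record, a 1.4-fold lower number from compound 1 to compound 2 (0.16 log units; within the scatter), swaps the whole aryl and stays within the scatter. For compound 3 the expected step in this assay is therefore none beyond the scatter, no change at the digits printed from compound 2 to compound 3 (within the scatter). Compound 3 is estimated at 1600 nM, range 700 nM to 3600 nM.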

Compound 3, half-maximal inhibitory concentration: 1100 nM
Compound 3: middle estimate off by 1.5-fold (0.16 log units), on the high side; the range from low to high includes it.
By their numbers in this assay, from the lowest: compounds 3, 2 and 1 (each within the scatter of the next, the first and the last beyond it).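

Isopropyl in place of propyl on the oxygen gives a 1.5-fold lower number from compound 2 to compound 3 (0.16 log units; within the scatter), so compound 2 and compound 3 are not told apart at this position. Going by these compounds alone, the aryl swap now reads a 2.1-fold lower number from compound 1 to compound 3 (0.32 log units; beyond the scatter), the first step beyond the scatter, though 4-propoxyphenyl in compound 2 did not separate from 2,4-difluorophenyl in compound 1. No measurement on hand accounts for either step.

Open, from the compounds shown here alone, is whether a tert-butyl or cyclopropyl on this oxygen separates from compound 3. Also open, going by these compounds, is whether an amine or carboxylic acid in place of the isopropoxy group does so.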